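Extending the Saturated Chain of Compound 1

The source may report more compounds than this note shows. Statements on the series, on what has been measured and on what is new or still open speak of the compounds shown alone.

Measured compounds:
Compound 1, `CCCCCCCCCCCCCCNC(=O)[C@@H](NC(=O)c1cc2ccccc2[nH]1)[C@@H](C)O`, in a functional assay on SW-620 cells (Homo sapiens) for cytotoxicity, read by MTT assay, with a stated time of 48 h; a lower number here means a stronger inhibitor, a higher number a weaker inhibitor: 15200 nM
Compound 2, `CCCCCCCCCCCCCCNC(=O)[C@@H](NS(=O)(=O)c1cccs1)[C@@H](C)O`, in this assay: 18400 nM

Within the data shown here, only two compounds have numbers. Compound 1 and compound 2 cannot be told apart on them: a 1.2-fold higher number from compound 1 to compound 2 (0.08 log units; within the scatter). Compound 1 is therefore simply one of two equivalent starting points.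

Compound 3, `CCCCCCCCCCCCCCCCCCNC(=O)[C@@H](NC(=O)c1cc2ccccc2[nH]1)[C@@H](C)O`, differs from compound 1 in one place: butyl in place of hydrogen on a saturated chain carbon, ten or more bonds along the chain from an amide-type nitrogen. Among the measured compounds shown here, the only measured step, from compound 1 to compound 2, swaps the group on the amine nitrogen and leaves the chain untouched, so nothing measured speaks directly to a longer chain. For the measured compounds named here, with no step to lean on, no shift beyond the scatter is expected for compound 3 in this assay.

Compound 3 is expected to give about 15000 nM in this assay, within a range of 5000 nM to 45000 nM, an expected step of a 1.0-fold lower number from compound 1 to compound 3 (0.01 log units; within the scatter).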

Compound 3, half-maximal inhibitory concentration: 23600 nM
Estimate against measurement, compound 3: 1.6-fold (0.20 log units) below; the range from low to high includes it.
By their numbers in this assay, from the lowest: compounds 1, 2 and 3 (each within the scatter of the next).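

Among these compounds, this is the first step that touches the chain itself: on a saturated chain carbon, butyl in place of hydrogen gives a 1.6-fold higher number from compound 1 to compound 3 (0.19 log units; within the scatter) in this assay on the core of compound 1. A step of this size cannot be told apart from repeat-measurement noise, so this extension shows no detectable effect on the number, something the earlier swap on the amine nitrogen could not reveal. No supporting data bear on why the number behaves this way.

The compounds shown compare just this one extension, so it remains open whether a shorter chain or a still longer chain would move the number beyond the scatter. Also open, as far as these compounds go, is whether an amine or a carboxylic acid at the chain end would read the same as the plain saturated chain.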